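Removing a chloro from an amide aryl in cell growth inhibitors

The source may hold more compounds than are shown below. What is called first, only, known or untested is meant among the compounds shown, and "the series" means these compounds.

Measured compounds:
- compound 1 `O=C(Nc1cccc(-n2cc(-c3ccncc3)c(-c3ccc(Cl)c(O)c3)n2)c1)Nc1ccc(Cl)c(Cl)c1`: 2890 nM
- compound 2 `COc1cc(-c2nn(-c3cccc(NC(=O)c4ccc(Cl)c(C(F)(F)F)c4)c3)cc2-c2ccncc2)ccc1Cl`: 7860 nM

In a functional assay on HCC 2998 cells (Homo sapiens) for inhibition, read by sulforhodamine B assay, with a stated time of 48 h (on this read-out lower numbers stand for stronger inhibition of growth and higher numbers for weaker inhibition of growth), compound 2 gives the highest of the two numbers, weaker than compound 1 by a gap beyond the scatter. Compound 3 `COc1cc(-c2nn(-c3cccc(NC(=O)c4cccc(C(F)(F)F)c4)c3)cc2-c2ccncc2)ccc1Cl` is not yet measured; it differs from compound 2 by hydrogen in place of chloro on an aromatic carbon, a change of a single heavy atom on an aromatic carbon. Going by the values given here, no step of this kind has been measured here, so the expected change a 1.3-fold higher number from compound 2 to compound 3 (0.10 log units; within the scatter) is small, most likely a modest weakening or none beyond the scatter. Compound 3 is therefore estimated at 10000 nM, within 4000 nM to 25000 nM.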

Compound 3, concentration for 50% growth inhibition: 2240 nM
Compound 3: the middle estimate sits 4.5-fold (0.65 log units) above what was measured, outside the stated range (below it).
By their numbers in this assay, from the lowest: compounds 3 and 1 (each within the scatter of the next); then compound 2.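

Removing the chloro, which turns 4-chloro-3-(trifluoromethyl)phenyl into 3-(trifluoromethyl)phenyl, gives a 3.5-fold lower number from compound 2 to compound 3 (0.55 log units; beyond the scatter) in this assay. Going by these compounds alone, this is the only step measured at this position, and it shows that this chloro is not needed for growth inhibition in this pair, where the compound without it inhibits more strongly. Nothing shown here explains the gain.

As far as these compounds go, whether an amine or a nitrile on this same carbon would give a lower or a higher number stays open. So does whether removing a chloro from the corresponding aryl of compound 1 would give a step of similar size.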